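A few compounds are considered here, and "the series" means these few. Any claim that something is new, unique, unknown or untested is made for them only; others in the source may bear on it.

Measured compounds:
Compound 1, `CCC/N=C(/NC#N)NCCCn1nc(-c2ccccc2)ccc1=O`, in a functional assay on the whole organism (stomach) with Rattus norvegicus as the target (a higher number here means that more compound is needed for the effect, a lower number that less compound is needed), gives 100 mg/kg.
Compound 2, `N#CNC(=N)NCCCn1nc(-c2ccccc2)ccc1=O`, reaches only the assay limit > 100 mg/kg in this assay.
Compound 3, `CC/N=C(/NC#N)NCCCn1nc(C)ccc1=O`, likewise gives only the limit > 100 mg/kg.

Compound 2 therefore stands at a limit of this assay rather than at a number. Going by the values given here, the single measured step leading to it, a number no lower from compound 1 to compound 2 (the limit leaves the size open), shows a dose that is no lower than for compound 1, with a size that cannot be read. Compound 4, `C/N=C(\S)NCCCn1nc(-c2ccccc2)ccc1=O`, differs from compound 2 by a group of 4 heavy atoms (2 carbon, 1 nitrogen, 1 sulfur; no ring) in place of a group of 5 heavy atoms (2 carbon, 3 nitrogen; no ring), on an amine nitrogen. Among the compounds with values here, no measured step covers this exchange; the only evidence bearing on it is the limit of > 100 mg/kg in this assay, at which 2 of the 3 values shown sit, so no direction beyond the scatter can be foreseen. Compound 4 is expected to give about 100 mg/kg, between 30 mg/kg and 300 mg/kg. The expected step of a number no higher from compound 2 to compound 4 (the limit leaves the size open) is thus small, and another limit is likely.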

Compound 4, dose for half-maximal effect: > 100 mg/kg
Compound 4: only a limit was reported; the forecaster's own chance of this, stated with the estimate: 60%; the middle value lies on the limit itself.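

In this assay compound 4 gives only a limit, > 100 mg/kg. The group of 4 heavy atoms with its sulfur therefore yields no readable number on this amine nitrogen either. Going by these compounds alone, the one step with a direction is a number no lower from compound 1 to compound 4 (the limit leaves the size open) and the step between the two limits cannot be read. The values now gather at one end of the assay: the limit of > 100 mg/kg in this assay, at which 3 of the 4 values shown sit.

On these data alone, how far beyond that limit compound 2 and compound 4 lie remains open. So does whether a longer chain than in compound 1, or a carboxylic acid, on this amine nitrogen would give a lower dose.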